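From 4-hydroxyphenyl to 2,4-dichlorophenyl in the series

A few compounds are considered here, and "the series" means these few. Any claim that something is new, unique, unknown or untested is made for them only; others in the source may bear on it.

In a functional assay on OVCAR-8 cells (Homo sapiens) (a higher number here means a weaker inhibitor of growth, a lower number a stronger inhibitor of growth), compound 1 `O=S(=O)(/C=C/c1ccc(Cl)c(Cl)c1)Cc1ccc(Nc2ncnc3ccc(Br)cc23)cc1` gives 100 nM. Compound 2 `O=S(=O)(/C=C/c1ccc(O)cc1)Cc1ccc(Nc2ncnc3ccc(Br)cc23)cc1` is reported as > 100000 nM, which is a limit of the assay and not a number. The next structure, compound 3 `O=S(=O)(/C=C/c1ccc(Cl)cc1Cl)Cc1ccc(Nc2ncnc3ccc(Br)cc23)cc1`, is reached from it by the change 2,4-dichlorophenyl in place of 4-hydroxyphenyl on a double-bonded chain carbon bound to a double-bonded chain carbon.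

Within the data shown here, one measured step bears on this, an at least 1000-fold higher number from compound 1 to compound 2 (3.00 log units; beyond the scatter). It is large and beyond the scatter, and it runs the opposite way, with 4-hydroxyphenyl entering in place of 3,4-dichlorophenyl. Among the measured compounds shown here, compound 3 also carries a dichlorophenyl, but no measured compound carries the 2,4-dichlorophenyl itself, so the reversal can only be read approximately. A large move toward a lower number in this assay is therefore expected, and the expected step is an at least 500-fold lower number from compound 2 to compound 3 (2.69 log units; beyond the scatter). Taking compound 1 at 100 nM as the guide, a value somewhat weaker is allowed for. Compound 3 is estimated at 200 nM, with an expected range of 40 nM to 2000 nM.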

Compound 3, concentration for 50% growth inhibition: 3000 nM
Compound 3: the middle estimate sits 15-fold (1.18 log units) below what was measured, and the stated range ends below it.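

Compound 2 in this assay is a limit of the assay and not a number: the limit of > 100000 nM in this assay, at which 1 of the 3 values shown sits.

Against that limit, the change to 2,4-dichlorophenyl gives an at least 33-fold lower number from compound 2 to compound 3 (1.52 log units; beyond the scatter), so a dichlorophenyl group other than the one in compound 1 also restores measurable growth inhibition at this place on a double-bonded chain carbon. The two dichlorophenyl groups are still not interchangeable: the comparison between them gives a 30-fold higher number from compound 1 to compound 3 (1.48 log units; beyond the scatter), although 3,4-dichlorophenyl and 2,4-dichlorophenyl differ only in where chlorine sits on the ring. This position therefore responds to the placement of chlorine and not merely to its presence, which the earlier pair, differing in both the groups on the ring and their placement, could not show.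

The compounds shown do not separate the effect of losing chlorine from that of gaining the hydroxyl, and a plain phenyl, a 4-chlorophenyl or a 3-chlorophenyl at this place would bear on that. Also open, from the compounds shown here alone, is how a 4-methoxyphenyl or a 2,6-dichlorophenyl would read in this assay.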